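Series notes: the ethyl to propyl step toward compound 4

The compounds below may be only part of what the source reports. "The series", "measured", "known", "first", "only" and "open" are said of these compounds alone.

Measured so far in a functional assay on the whole organism (blood, strain albino) with Mus musculus as the target, with stated times of 6 days and 4 h, at a dose of 1 mmol/kg by the oral route; on this read-out higher numbers stand for more inhibition at the one dose given (going by the name of the read-out) and lower numbers for less inhibition:
compound 1 `CCN1C(=O)CN(S(=O)(=O)c2ccc(-n3nc(C(=O)O)cc3C)cc2)C1=S` gives < 1%
compound 2 `CCN1C(=O)CN(S(=O)(=O)c2ccc(-n3nc(C)cc3C)cc2)C1=S` gives < 1%
compound 3 `C=CCN1C(=O)CN(S(=O)(=O)c2ccc(-n3nc(C(=O)O)cc3C)cc2)C1=S` gives < 1%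

The value of compound 1 is a limit of this assay, not a number. The value of compound 2 is likewise a limit. The value of compound 3 is also a limit. Compound 2 thus stands at the limit, as the limit of < 1% in this assay, at which 3 of the 3 values shown sit, records. The steps a step that the two limits leave unreadable from compound 1 to compound 2 and a step that the two limits leave unreadable from compound 1 to compound 3 both run between limits and give no readable size. Compound 4 `CCCN1C(=O)CN(S(=O)(=O)c2ccc(-n3nc(C)cc3C)cc2)C1=S` differs from compound 2 by methyl in place of hydrogen on a saturated chain carbon, two bonds along the chain from an amide-type nitrogen in a ring; cut one bond further out this reads ethyl to propyl. For the measured compounds named here, no measured step touches that position, so nothing points to a change beyond the scatter. Compound 4 is expected to stay at the limit, with an estimated step of a number no lower from compound 2 to compound 4 (the limit leaves the size open). The estimate for compound 4 is 1%, ranging from 0% to 12%.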

Compound 4, a percentage reported as inhibition, in the whole organism at one dose (the size of the read-out at that dose, not a potency): < 1%
Compound 4: only a limit was reported (the forecaster's own chance of this, stated with the estimate: 75%); the middle value sits exactly at the limit.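

The step between compound 2 and compound 4 cannot be read, as both values are only limits: the limit of < 1% in this assay, at which 4 of the 4 values shown sit.

The compounds shown leave open whether any change in this series gives measurable inhibition, and so what ethyl to propyl does.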